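The compounds below may be only part of what the source reports. "The series", "measured", "known", "first", "only" and "open" are said of these compounds alone.

Compound 1 `COc1cccc(/C=C/C(=O)c2ccc(OC)c3c2OC(C)(C)C=C3)c1`: in a functional assay on HT-29 cells (Homo sapiens) for antiproliferative activity, read by MTT assay, with a stated time of 24 h (on this read-out higher numbers stand for weaker inhibition and lower numbers for stronger inhibition), compound 1 gives > 10000 nM, which is a limit of the assay rather than a number.
Compound 2 `COc1ccc(C(=O)/C=C/c2cc(OC)c(OC)c(OC)c2)c2c1C=CC(C)(C)O2`: in this assay compound 2 gives > 10000 nM, again a limit.
Compound 3 `COc1ccc(/C=C/C(=O)c2ccc(OC)c3c2OC(C)(C)C=C3)c(F)c1`: in this assay compound 3 gives > 10000 nM, also a limit.

All three measured compounds share the same core and sit at the same place, (the limit of > 10000 nM in this assay, at which 3 of the 3 values shown sit), so compound 3 stands nowhere in particular within the set: it is as unreadable as its neighbours. Going by the values given here, the only single-place step between measured compounds, a step that the two limits leave unreadable from compound 1 to compound 3, runs from one limit to another and its size cannot be read.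

Compound 4 `COc1ccc(C(=O)/C=C/c2ccc(F)cc2)c2c1C=CC(C)(C)O2` differs from compound 3 by 4-fluorophenyl in place of 2-fluoro-4-methoxyphenyl on a double-bonded chain carbon bound to a double-bonded chain carbon. Among the compounds with values here, no measured step bears directly on this change, and the one step that exists is unreadable, so the data give no direction to expect; any movement beyond the scatter would be a surprise rather than a prediction. Compound 4 is therefore expected to come out near 12000 nM, between 3000 nM and 50000 nM, most likely again as a limit. The expected step is a step that the limit leaves unreadable from compound 3 to compound 4, that is, none beyond the scatter.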

Compound 4, half-maximal inhibitory concentration: > 10000 nM
Compound 4 gave a limit, no number; the forecaster's own chance of this, stated with the estimate: 80%; the middle value lies beyond the limit too.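

The steps from compound 3 to compound 4 and from compound 1 to compound 4 cannot be read, as each runs from one limit to another: the limit of > 10000 nM in this assay, at which 4 of the 4 values shown sit.

The compounds shown leave open which change, if any, would give a readable number in this assay.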